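Notes on swapping diethylamino for piperidin-1-yl

The compounds below may be only part of what the source reports. "The series", "measured", "known", "first", "only" and "open" are said of these compounds alone.

Values in a functional assay on HCT-116 cells (Homo sapiens) for antiproliferative activity, read by MTT assay, with a stated time of 48 h; a lower number here means a stronger inhibitor, a higher number a weaker inhibitor:
- compound 1 `COc1c(OCCCN2CCCCC2)cc2oc(-c3ccccc3)cc(=O)c2c1O`: 22100 nM
- compound 2 `CCN(CC)CCCCOc1cc2oc(-c3ccccc3)cc(=O)c2c(O)c1OC`: 5100 nM
- compound 3 `COc1c(OCCCCN2CCCCC2)cc2oc(-c3ccccc3)cc(=O)c2c1O`: not yet measured

Among the measured compounds shown here, compound 2 holds the lower of the two measured numbers, and compound 1 is the only neighbour. The change to compound 3 is piperidin-1-yl in place of diethylamino on a saturated chain carbon, four bonds along the chain from an oxygen on an aromatic ring. For the measured compounds named here, one measured step bears on this: a 4.3-fold lower number from compound 1 to compound 2 (0.64 log units; beyond the scatter), a modest step. That step alters the chain and the amine group together, and the data do not separate the two. Compound 3 keeps the chain of compound 2 and carries the piperidin-1-yl of compound 1, so part of that step may be given back. The expected step in this assay is a 1.9-fold higher number from compound 2 to compound 3 (0.27 log units; within the scatter), towards a higher number. For compound 3 the estimated value is 9500 nM, with an expected range of 3500 nM to 25000 nM.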

Compound 3, half-maximal inhibitory concentration: 3000 nM
For compound 3 the middle estimate is 3.2-fold (0.50 log units) above the measured one; the measured number lies below the stated range.
By their numbers in this assay, from the lowest: compounds 3 and 2 (each within the scatter of the next); then compound 1.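

In this assay, the step with piperidin-1-yl kept and the chain extended, (piperidin-1-yl)methyl in place of piperidin-1-yl on a saturated chain carbon, is (a 7.4-fold lower number from compound 1 to compound 3 (0.87 log units; beyond the scatter)), so the chain change alone is now seen to lie beyond the scatter. On the longer chain, the swap of diethylamino for piperidin-1-yl gives (a 1.7-fold lower number from compound 2 to compound 3 (0.23 log units; within the scatter)), so at this chain length these two amines are not told apart. No measurement on hand offers a reason for either step.

Among the compounds shown here, open is whether the two amines also match on the shorter chain, as the series holds no diethylamino compound there. Also open, from the compounds shown here alone, is how a still longer chain, or a morpholine ring in place of piperidin-1-yl, would read in this assay on the shared core.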